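Methyl for amino on the core: expected shift for compound 4

A few compounds are considered here, and "the series" means these few. Any claim that something is new, unique, unknown or untested is made for them only; others in the source may bear on it.

Measured in a physicochemical assay for lipophilicity, at pH 7.4; a lower number here means a more polar compound, a higher number a more lipophilic compound:
- compound 1 `C[C@H](Nc1nc(N)nc(N)c1C#N)c1cc2ccc(F)cn2c(=O)c1-c1ccccc1`: 1.26
- compound 2 `C[C@H](Nc1nc(N)nc(N)c1C#N)c1c(-c2ccccc2)c(=O)n2cc(F)ccc2c1-c1ccccc1`: 2.49
- compound 3 `C[C@H](Nc1nc(N)nc(N)c1C#N)c1c(-c2ccccc2)c(=O)n2cc(F)ccc2c1-c1ccc(F)cc1`: 2.38

Compound 3 stands second highest of the three in this assay; against compound 2 the step of a number 0.11 log units lower from compound 2 to compound 3 (within the scatter) lies within the scatter, against compound 1 the step of a number 1.12 log units higher from compound 1 to compound 3 (beyond the scatter) is large. The large steps of a number 1.23 log units higher from compound 1 to compound 2 (beyond the scatter) and a number 1.12 log units higher from compound 1 to compound 3 (beyond the scatter) come from a phenyl or 4-fluorophenyl entering on the core.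

Compound 4 `Cc1nc(N)nc(N[C@@H](C)c2c(-c3ccccc3)c(=O)n3cc(F)ccc3c2-c2ccc(F)cc2)c1C#N` differs from compound 3 by methyl in place of amino on an aromatic carbon. Going by the values given here, no measured step touches this part of the core, so none bears on it directly; the change removes one hydrogen-bond donor and one acceptor and adds none. A moderate rise in this assay beyond the scatter is therefore expected, a number 0.67 log units higher from compound 3 to compound 4 (beyond the scatter). Compound 4 is estimated at 3.05, range 2.6 to 3.5.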

Compound 4, distribution coefficient: 3.26
Compound 4: the middle estimate sits 0.21 log units below what was measured, within the range that was stated.
By their numbers in this assay, from the lowest: compound 1; then compounds 3 and 2 (each within the scatter of the next); then compound 4.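

In this assay, methyl in place of amino at the 2,6-diamino-5-cyanopyrimidin-4-yl group gives a step of a number 0.88 log units higher from compound 3 to compound 4 (beyond the scatter) and is the only step shown at this position. Going by these compounds alone, this place on the core, untouched by the earlier steps, therefore does register in this read-out. No measurement on hand accounts for the size of this step.

A single pair cannot separate the loss of amino from the gain of methyl. Chloro, methoxy or ethyl on the same aromatic carbon would show how the number tracks the group there.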